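Pyrrolidin-1-yl in place of dimethylamino on a carbonyl carbon

A few compounds are considered here, and "the series" means these few. Any claim that something is new, unique, unknown or untested is made for them only; others in the source may bear on it.

Compound 1 `Cc1ccc([C@H](C(=O)N(C)C)N2C(=O)[C@@H](C3Cc4ccccc4C3)NC(=O)[C@H]2CC(C)C)cn1`: 18 mL/min/kg
Compound 2 `CC[C@H](C)[C@@H]1C(=O)N[C@H](C2Cc3ccccc3C2)C(=O)N1[C@@H](C(=O)N(C)C)c1ccc(C)nc1C`: 15 mL/min/kg

In an in vivo ADME assay on the whole organism for pharmacokinetics, with Rattus norvegicus as the target, at a dose of 5 mg/kg (on this read-out lower numbers stand for slow clearance and higher numbers for fast clearance), compound 1 gives 18 mL/min/kg, and compound 2 gives 15 mL/min/kg, so the two stand level within the usual scatter. Compound 3 `Cc1ccc([C@H](C(=O)N2CCCC2)N2C(=O)[C@@H](C3Cc4ccccc4C3)NC(=O)[C@H]2CC(C)C)cn1` keeps the core of compound 1 and differs by one change: pyrrolidin-1-yl in place of dimethylamino on a carbonyl carbon. Going by the values given here, no measured pair shows this change, so the expectation rests on the structure alone: a small upward step at most, probably not beyond the scatter. The estimated step is a 1.2-fold higher number from compound 1 to compound 3 (0.07 log units; within the scatter). For compound 3 the expected clearance is 21 mL/min/kg, with an estimated range of 11 mL/min/kg to 38 mL/min/kg.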

Compound 3, clearance: 33 mL/min/kg
Compound 3: middle estimate off by 1.6-fold (0.20 log units), on the low side, within the range that was stated.
By their numbers in this assay, from the lowest: compounds 2, 1 and 3 (each within the scatter of the next, the first and the last beyond it).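

In this assay, going by these compounds alone, the change from dimethylamino to pyrrolidin-1-yl on a carbonyl carbon gives a 1.8-fold higher number from compound 1 to compound 3 (0.26 log units; within the scatter) and so offers the first single-place reading at this position, where the added ring leaves a step that cannot be told from repeat measurement. Compound 2 differs from compound 1 in more than one place and could not show this. Nothing measured here gives a reason for the values. Still open, on these data alone, is whether piperidin-1-yl or morpholin-4-yl on the same carbonyl carbon would stay within the scatter of compound 1. Also open, as far as these compounds go, is whether pyrrolidin-1-yl reads the same on the core of compound 2.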